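Replacing 4-acetylpiperazin-1-yl with pyrrolidin-1-yl

The compounds below may be only part of what the source reports. "The series", "measured", "known", "first", "only" and "open" are said of these compounds alone.

In a functional assay on ECa-109 cells for inhibition, with ECa-109 cell line (Homo sapiens) as the target, read by MTT assay, with a stated time of 48 h (on this read-out lower numbers stand for stronger inhibition and higher numbers for weaker inhibition), compound 1 `COc1ccc(-c2coc3cc(OCCCBr)ccc3c2=O)cc1` gives 39700 nM and compound 2 `COc1ccc(-c2coc3cc(OCCCSC(=S)N4CCN(C(C)=O)CC4)ccc3c2=O)cc1` gives 24700 nM. Among the compounds with values here, compound 2 therefore stands within the scatter of compound 1, the only other measured number. Compound 3 `COc1ccc(-c2coc3cc(OCCCSC(=S)N4CCCC4)ccc3c2=O)cc1` carries pyrrolidin-1-yl in place of 4-acetylpiperazin-1-yl on a thiocarbonyl carbon. Within the data shown here, no measured pair shows this change, so no step beyond the scatter is expected in this assay, in either direction. The estimated 1.1-fold lower number from compound 2 to compound 3 (0.05 log units; within the scatter) stays inside the scatter. For compound 3 the expected value is 22000 nM, with an estimated range of 9000 nM to 50000 nM.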

Compound 3, half-maximal inhibitory concentration: 30800 nM
Estimate against measurement, compound 3: 1.4-fold (0.15 log units) below; the range from low to high includes it.
By their numbers in this assay, from the lowest: compounds 2, 3 and 1 (each within the scatter of the next).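

In this assay, pyrrolidin-1-yl in place of 4-acetylpiperazin-1-yl on a thiocarbonyl carbon gives a 1.2-fold higher number from compound 2 to compound 3 (0.10 log units; within the scatter), so this first change at this position does not separate the two groups. The group of 8 heavy atoms in place of the bromine atom gives a 1.3-fold lower number from compound 1 to compound 3 (0.11 log units; within the scatter), so neither change yet moves the read-out beyond the scatter. Nothing measured offers an explanation for either step. Open, as far as these compounds go, is whether morpholin-4-yl or dimethylamino on the thiocarbonyl carbon, or a longer chain, would give a step beyond the scatter.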